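The source may hold more compounds than are shown below. What is called first, only, known or untested is meant among the compounds shown, and "the series" means these compounds.

Measured compounds:
compound 3, `Cc1c(Nc2ccc(C#N)cc2Cl)ncnc1OC1C2COCC1CN(C(=O)OC1(C)CC1)C2`: 4 nM
compound 2, `Cc1c(Nc2ccc(S(C)(=O)=O)cc2F)ncnc1OC1CC2COCC(C1)N2C(=O)OC1(C)CC1`: 70 nM
compound 1, `Cc1c(Nc2ccc(C#N)cc2Cl)ncnc1OC1C2COCC1CN(S(=O)(=O)C1CC1)C2`: 51 nM; 1210 nM (2 entries)

In a functional assay on HEK293 cells for agonist activity at Glucose-dependent insulinotropic receptor (Homo sapiens), read by fluorescence and cAMP accumulation, with a stated time of 30 min (a lower number here means that less compound is needed, a higher number that more compound is needed for the effect), compound 3 holds the lowest of the two single numbers; the nearest, compound 2, stands beyond the scatter above it. Compound 1 has no single number, only the spread of repeated entries in the several entries of compound 1 in this assay, 51 nM; 1210 nM (2 entries), which is left aside.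

Compound 4, `CC1(OC(=O)N2CC3COCC(C2)C3Oc2cc(Nc3ccc(C#N)cc3Cl)ncn2)CC1`, differs from compound 3 by hydrogen in place of methyl on an aromatic carbon, a hydrogen in place of methyl on an aromatic carbon of the shared core. Among the measured compounds shown here, no measured pair shows this change, so the step from compound 3 to compound 4 is an expectation only: a moderate rise in the number, a 5.0-fold higher number from compound 3 to compound 4 (0.70 log units; beyond the scatter). Compound 4 is therefore estimated at 20 nM, with a range of 4 nM to 100 nM.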

Compound 4, half-maximal effective concentration: 25 nM
Beside the measured number, compound 4's estimate is 1.3-fold (0.10 log units) below it; low and high end bracket the measured number.
By their numbers in this assay, from the lowest: compound 3; then compound 4; then compound 2.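

Hydrogen in place of methyl on this aromatic carbon of the shared core, ortho to a (2-chloro-4-cyanophenyl)amino group, gives the only one-place comparison so far: in this assay the result is a 6.3-fold higher number from compound 3 to compound 4 (0.80 log units; beyond the scatter). The methyl therefore counts at this position, though compound 4 still gives a measurable response without it. Nothing measured here accounts for the size of this step.

Going by these compounds, whether an ethyl group, a methoxy group or an amine at this carbon would lower or raise the number remains open. Also open, on these data alone, is whether the step carries over to the cores of compound 1 and compound 2.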